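Urea series: trifluoromethoxy to fluoro on the terminal ring

The source may report more compounds than this note shows. Statements on the series, on what has been measured and on what is new or still open speak of the compounds shown alone.

Compound 1 `Cc1cc(C)nc(Sc2ccc(NC(=O)Nc3ccccc3)cc2)n1` in a functional assay on MCF7 cells (Homo sapiens) for cytotoxicity, read by MTT assay, with a stated time of 3 days (on this read-out lower numbers stand for stronger inhibition and higher numbers for weaker inhibition), gives > 50000 nM, a limit of the assay and not a number.
Compound 2 `Cc1cccc(NC(=O)Nc2ccc(Sc3nc(C)cc(C)n3)cc2)c1` in this assay gives 37000 nM.
Compound 3 `Cc1cc(C)nc(Sc2ccc(NC(=O)Nc3ccc(OC(F)(F)F)cc3)cc2)n1` in this assay gives 41700 nM.

Compound 3 stands at the highest of the two numbers shown; compound 2 sits within the scatter of it, and compound 1 contributes only a limit. Compound 4 `Cc1cc(C)nc(Sc2ccc(NC(=O)Nc3ccc(F)cc3)cc2)n1` differs from compound 3 by fluoro in place of trifluoromethoxy on an aromatic carbon.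

The measured steps that bear on this change are both substitutions of hydrogen on the same ring, each starting from the limit of > 50000 nM in this assay, at which 1 of the 3 values shown sits: an at least 1.3-fold lower number from compound 1 to compound 2 (0.13 log units; that floor lies within the scatter) and an at least 1.1-fold lower number from compound 1 to compound 3 (0.07 log units; that floor lies within the scatter). Both floors lie within the scatter, and the two substituted compounds are within the scatter of each other, so swapping one group on this ring for another has so far produced no step beyond the scatter in this assay.

For compound 4 the expected step is a 1.1-fold higher number from compound 3 to compound 4 (0.03 log units; within the scatter), within the scatter. Compound 4 is therefore estimated at 45000 nM, with a range from 22000 nM to 90000 nM.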

Compound 4, half-maximal inhibitory concentration: > 50000 nM
Compound 4 gave a limit, no number (the forecaster's own chance of this, stated with the estimate: 40%); at least 1.1-fold (0.04 log units) between middle value and limit.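

With compound 4, a second member of the series returns a limit and not a number in this assay: the limit of > 50000 nM in this assay, at which 2 of the 4 values shown sit.

Fluoro in place of trifluoromethoxy gives an at least 1.1-fold higher number from compound 3 to compound 4 (0.07 log units; that floor lies within the scatter), and the exchange of the whole terminal aryl group gives an at least 1.3-fold higher number from compound 2 to compound 4 (0.13 log units; that floor lies within the scatter), so neither floor shows a step beyond the scatter. The step from compound 1 to compound 4 cannot be read, as both values are limits.

On these data alone, how far the true value of compound 4 lies past the limit stays open, and so does the full size of this change. Also open, as far as these compounds go, is whether an amine or a carboxylic acid on this aromatic carbon would give a step beyond the scatter in this assay.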